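Compound 3 to compound 4 at the assay limit

The compounds below may be only part of what the source reports. "The series", "measured", "known", "first", "only" and "open" are said of these compounds alone.

In a functional assay on A549 cells (Homo sapiens) for cytotoxicity, read by MTT assay, with a stated time of 48 h (a lower number here means a stronger inhibitor, a higher number a weaker inhibitor), compound 1 (`C=CC(C)(O)CC[C@@H]1C(=C)CC[C@H](Br)[C@@]1(C)CCC(O)C(C)(C)O`) gives > 100000 nM as a limit and not a number. Compound 2 (`C=CC(C)(O)CC[C@@H]1C(=C)CC[C@H](Br)[C@@]1(C)CCC(OC)C(C)(C)O`) gives > 100000 nM as a limit too. Compound 3 (`C=CC(C)(O)CC[C@@H]1C(=C)CC[C@H](Br)[C@@]1(C)CCC(=O)C(C)C`) stands at > 100000 nM which is likewise a limit. All three share it (the limit of > 100000 nM in this assay, at which 3 of the 3 values shown sit). Compound 4 (`C=CC(C)(O)CC[C@@H]1C(=C)CC[C@H](Br)[C@@]1(C)CCC(O)C(=C)C`) carries 1-hydroxy-2-methylprop-2-en-1-yl in place of isopropylcarbonyl on a saturated chain carbon, two bonds along the chain from a saturated ring carbon. The steps bearing on this change (a step that the two limits leave unreadable from compound 1 to compound 3 and a step that the two limits leave unreadable from compound 2 to compound 3) have no readable size, nor has the remaining one (a step that the two limits leave unreadable from compound 1 to compound 2) so none gives a direction. In this assay no step beyond the scatter is expected (a number no higher from compound 3 to compound 4 (the limit leaves the size open)) in either direction. Compound 4 is estimated at 100000 nM with an expected range from 30000 nM to 200000 nM and most likely only a limit reported.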

Compound 4, half-maximal inhibitory concentration: > 100000 nM
Compound 4 was reported as a limit; the forecaster's own chance of this, stated with the estimate: 80%; the middle value sits exactly at the limit.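

Compound 4 joins compound 1, compound 2 and compound 3 at the same limit, so no step among them can be read in this assay: the limit of > 100000 nM in this assay, at which 4 of the 4 values shown sit.

The compounds shown leave open whether any of these changes shifts the half-maximal inhibitory concentration at all, and in which direction.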